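Aryl ring change and expected permeability in a series

This account rests on a few compounds, and the source may have more. Where it says the series, first, only, none or still open, it means among the compounds named here.

Compound 1 `Cc1cc(C)c(-c2nc(CN3CCC(C(=O)NCCCN4C[C@H](C)C[C@H](C)C4)CC3)c(C)o2)c(C)c1` stands without a number in a physicochemical assay for permeability, using PAMPA; on this read-out higher numbers stand for higher permeability and lower numbers for lower permeability: its result is recorded as "not determined" (no result reported). Two related compounds do carry numbers. Compound 2 `Cc1ccccc1-c1nc(CN2CCC(C(=O)NCCCN3CCCCC3)CC2)c(C)o1` gives 34.5 10^-6 cm/s in this assay, and compound 3 `Cc1ccccc1-c1nc(CN2CCC(C(=O)NCCCN3CCCC(CC(C)C)C3)CC2)c(C)o1` gives 3 10^-6 cm/s. For the measured compounds named here, the one step between them, a 12-fold lower number from compound 2 to compound 3 (1.06 log units; beyond the scatter), shows that adding an isobutyl group on the saturated ring lowered the read-out sharply.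

Compound 4 `Cc1ccc(-c2nc(CN3CCC(C(=O)NCCCN4C[C@H](C)C[C@H](C)C4)CC3)c(C)o2)cc1C` is the compound still to be measured. It differs from compound 1 in one place: 3,4-dimethylphenyl in place of 2,4,6-trimethylphenyl on an aromatic carbon. This change sits on the aromatic carbon of the five-membered ring, far from the saturated ring where the step from compound 2 to compound 3 took place, so that step does not bear directly on it. Going by the values given here, no measured step touches the aryl group, and compound 1 itself has no number, so there is no starting point from which a direction can be read. Among the compounds with values here, the only anchors are the values of compound 2 and compound 3, which bracket the range seen so far.

Compound 4 is therefore expected to give about 10 10^-6 cm/s in this assay, with a likely range from 3 10^-6 cm/s to 35 10^-6 cm/s.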

Compound 4, apparent permeability: 219 10^-6 cm/s
Estimate against measurement, compound 4: 22-fold (1.34 log units) below, outside the stated range (above it).
By their numbers in this assay, from the lowest: compound 3; then compound 2; then compound 4.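

No new step can be read from compound 4 in this assay: compound 1, its one-place partner, has no number there, and compound 2 and compound 3 differ from it in more than one place. The compounds shown leave open how 3,4-dimethylphenyl in place of 2,4,6-trimethylphenyl shifts this read-out. No evidence here explains the result for compound 4.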